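Fluoro in Place of Cyano on the Acid-Bearing Ring

This account rests on a few compounds, and the source may have more. Where it says the series, first, only, none or still open, it means among the compounds named here.

Compound 2 `Cc1nn(-c2ccccn2)c2cc(-c3ccc(CCC(=O)O)cc3C#N)ccc12` reaches 47% in a functional assay on cells for agonist activity at Free fatty acid receptor 1 (Mus musculus), read by FLIPR and calcium flux, with a stated time of 5 min (a higher number here means a larger maximal response, a lower number a smaller maximal response), the lower of the two measured values. Within the data shown here, its neighbour, compound 1 `COc1cc(CCC(=O)O)ccc1-c1ccc2c(C)nn(-c3ccccn3)c2c1`, gives 62% in this assay, and the only recorded step, a number 15 percentage points lower from compound 1 to compound 2 (beyond the scatter), concerns the same ring position that changes next. Compound 3 `Cc1nn(-c2ccccn2)c2cc(-c3ccc(CCC(=O)O)cc3F)ccc12` differs from compound 2 by fluoro in place of cyano on an aromatic carbon. Among the measured compounds shown here, no measured pair exchanges cyano for fluoro, so the one step that bears on it is a number 15 percentage points lower from compound 1 to compound 2 (beyond the scatter), which shows that a change of the group at this position can shift the maximal response by a modest, measurable amount. Because compound 2 sits at 47% and compound 1 at 62%, the expected value for compound 3 is placed between them, with an estimated step of a number 8 percentage points higher from compound 2 to compound 3 (within the scatter). Compound 3 is therefore expected to give about 55%, within a range of 40% to 70%.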

Compound 3, largest response reached (reported as efficacy), in percent of the reference or control that the assay uses: 105%
Estimate against measurement, compound 3: 50 percentage points below, and the stated range ends below it.
By their numbers in this assay, from the lowest: compound 2; then compound 1; then compound 3.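

At this position on the carbon-only aromatic ring, ortho to a large group and meta to a 2-carboxyethyl group, the exchange of cyano for fluoro gives a number 58 percentage points higher from compound 2 to compound 3 (beyond the scatter) in this assay, a far larger shift than the earlier methoxy-to-cyano step suggested. Fluoro also surpasses methoxy at the same place, with a number 43 percentage points higher from compound 1 to compound 3 (beyond the scatter) in this assay, so the position can support a much larger maximal response than either earlier compound indicated. Nothing at hand accounts for the size of this rise.

The compounds shown leave open whether chloro, methyl or trifluoromethyl at this place would give a similar maximal response, or whether the result is particular to fluoro. They also leave open whether a second fluoro on the same ring would add to the response or reduce it.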